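The source may report more compounds than this note shows. Statements on the series, on what has been measured and on what is new or still open speak of the compounds shown alone.

Measured compounds in an ADME assay on MRC5 cells (Homo sapiens) for cytotoxicity, read by resazurin assay, with a stated time of 72 h; a lower number here means a stronger inhibitor, a higher number a weaker inhibitor:

compound 1, `CC1(COc2ccc(-c3ccc(F)nc3F)cn2)CCn2cc([N+](=O)[O-])nc2O1`, gives > 64000 nM in this assay; this value is a limit of the assay, not a number.

compound 2, `O=[N+]([O-])c1cn2c(n1)OC(COc1ncc(-c3ccc(F)nc3)cn1)CC2`, gives > 64000 nM in this assay; this too is a limit of the assay, not a number.

For the measured compounds named here, compound 2 stands where every value so far stands: at the limit of > 64000 nM in this assay, at which 2 of the 2 values shown sit. Nothing in the recorded values separates compound 2 from compound 1, since neither is a number. Going by the values given here, no step between two measured compounds is available, so nothing is known about how any change on this shared core moves this assay.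

The next compound, compound 3, `O=[N+]([O-])c1cn2c(n1)OC(COc1ncc(-c3ccc(F)cc3)cn1)CC2`, differs from compound 2 in one place: 4-fluorophenyl in place of 6-fluoropyridin-3-yl on an aromatic carbon.

With both recorded values sitting at the same limit, the expectation for the step from compound 2 to compound 3 is none beyond the scatter, and compound 3 is expected to remain at the limit, a step that the limit leaves unreadable from compound 2 to compound 3. The estimate for compound 3 in this assay is 80000 nM, with an expected range from 40000 nM to 200000 nM, most likely reported again only as a limit.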

Compound 3, half-maximal inhibitory concentration: > 64000 nM
Compound 3 was reported as a limit; the forecaster's own chance of this, stated with the estimate: 85%; the middle value lies beyond the limit too.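

In this assay no step can be read from compound 2 to compound 3, as both values are limits of the assay and not numbers: the limit of > 64000 nM in this assay, at which 3 of the 3 values shown sit.

The compounds shown leave open whether 4-fluorophenyl in place of 6-fluoropyridin-3-yl, or any other change on the shared core, moves the result in this assay at all.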